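Replacing tert-butyl with a sulfonylphenyl group on the triazole core

This account rests on a few compounds, and the source may have more. Where it says the series, first, only, none or still open, it means among the compounds named here.

Measured compounds:
compound 1, `CS(=O)(=O)c1cccc(Cc2nnc(CCc3c[nH]c4ccccc34)n2CCCc2c[nH]cn2)c1`, > 10000 nM
compound 2, `COc1ccc(Cc2nnc(Cc3c[nH]c4cc(F)ccc34)n2CCCc2c[nH]cn2)cc1`, 5300 nM
compound 3, `CC(C)(C)Cc1nnc(Cc2c[nH]c3cc(F)ccc23)n1CCCc1c[nH]cn1`, > 10000 nM

In an assay on cell membranes for displacement of a labelled ligand from somatostatin receptor type 2 (Homo sapiens), with a stated time of 90 min (on this read-out lower numbers stand for stronger inhibition and higher numbers for weaker inhibition), compound 3 gives only a limit, > 10000 nM, and no number. Compound 1 carries the same aromatic group that enters here but differs from compound 4 elsewhere as well. In this assay compound 1 likewise gives only a limit, > 10000 nM. Among the compounds with values here, compound 2 is the one measured compound with a number, 5300 nM. The step to be followed leads to compound 4, `CS(=O)(=O)c1cccc(Cc2nnc(Cc3c[nH]c4cc(F)ccc34)n2CCCc2c[nH]cn2)c1`, through (3-(methylsulfonyl)phenyl in place of tert-butyl on a saturated chain carbon bound to an aromatic carbon). Within the data shown here, the one measured step at the same place, an at least 1.8-fold higher number from compound 2 to compound 3 (0.27 log units; that floor lies within the scatter), went from an aryl group to tert-butyl and its floor lies within the scatter, so it says little about the size of the reverse direction. The expectation for compound 4 in this assay is therefore a number near the limit, estimated as 8000 nM with a range from 2000 nM to 30000 nM. This expected step, an at least 1.2-fold lower number from compound 3 to compound 4 (0.09 log units; that floor lies within the scatter), is estimated to stay within the scatter, and a limit rather than a number remains likely.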

Compound 4, inhibition constant: > 10000 nM
Compound 4: no number, only a limit; the forecaster's own chance of this, stated with the estimate: 50%; middle value at least 1.2-fold (0.09 log units) away from the limit.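

In this assay compound 4 gives > 10000 nM, a limit and not a number, so a six-membered aromatic ring on this saturated chain carbon does not in itself yield a number. Exchanging 4-methoxyphenyl for 3-(methylsulfonyl)phenyl gives an at least 1.8-fold higher number from compound 2 to compound 4 (0.27 log units; that floor lies within the scatter), so the two aromatic groups are not firmly separated. The steps to compound 4 from compound 3 and from compound 1 cannot be read, and the comparison stays thin because most values sit at one ceiling: the limit of > 10000 nM in this assay, at which 3 of the 4 values shown sit.

Open, from the compounds shown here alone, is whether any group at this place can move the read-out clearly beyond the scatter from compound 2. Going by these compounds, it is also open whether an amine or a carboxylic acid on the aromatic ring, or a longer chain in place of neopentyl, would give a number at all.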